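Lengthening the amine chain from compound 3 to compound 4

The source may report more compounds than this note shows. Statements on the series, on what has been measured and on what is new or still open speak of the compounds shown alone.

Compound 1, `CCN(CC)Cc1ccc(Cl)c(-c2ccccc2OC)c1`: in an assay on isolated protein for binding affinity to 5-hydroxytryptamine receptor 6 (Homo sapiens) (on this read-out lower numbers stand for stronger inhibition and higher numbers for weaker inhibition), compound 1 gives 2000 nM.
Compound 2, `COc1ccccc1-c1cc(C2CCN(C)C2)ccc1Cl`: compound 2 gives only > 10000 nM, which is a limit of the assay and not a number.
Compound 3, `CNCc1ccc(Cl)c(-c2ccccc2OC)c1`: compound 3 gives 1300 nM.

All three share one core; they differ only in the amine-bearing group attached to it. Compound 3 has the lowest of the two numbers shown, but its nearest neighbour is compound 1, with a 1.5-fold lower number from compound 1 to compound 3 (0.19 log units; within the scatter), so the two cannot be ranked against each other. Compound 2 sits at the limit of > 10000 nM in this assay, at which 1 of the 3 values shown sits, and the move from compound 2 to compound 3 is an at least 7.6-fold lower number from compound 2 to compound 3 (0.88 log units; beyond the scatter).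

Compound 4, `CCCNCc1ccc(Cl)c(-c2ccccc2OC)c1`, is not yet measured. It differs from compound 3 by ethyl in place of hydrogen on a saturated chain carbon bound to an amine nitrogen. Among the compounds with values here, the only measured step that touches the same part of the molecule is the one from compound 1 to compound 3, a swap of methylamino for diethylamino: a 1.5-fold lower number from compound 1 to compound 3 (0.19 log units; within the scatter). That step stayed within the scatter, so changing the size of the alkyl groups on this nitrogen has so far moved the number little. For compound 4 the expected step is therefore a 1.2-fold higher number from compound 3 to compound 4 (0.06 log units; within the scatter), within the scatter. Compound 4 is estimated at 1500 nM, with a likely range from 600 nM to 4000 nM.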

Compound 4, inhibition constant: 3500 nM
Estimate against measurement, compound 4: 2.3-fold (0.37 log units) below; measured number inside the range.
By their numbers in this assay, from the lowest: compounds 3, 1 and 4 (each within the scatter of the next, the first and the last beyond it). At a limit, above all of these: compound 2.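

In this assay, within the data shown here, the step from methylamino to propylamino is the first change of alkyl size on this nitrogen to move the number beyond the scatter: a 2.7-fold higher number from compound 3 to compound 4 (0.43 log units; beyond the scatter). That gives the chain a modest sensitivity that the earlier comparison did not reveal, yet compound 1 fits no simple rule based on size, since its diethylamino group stays within the scatter of both other amines, including this step: a 1.8-fold higher number from compound 1 to compound 4 (0.24 log units; within the scatter). The longer chain still leaves (propylamino)methyl on the favourable side of the 1-methylpyrrolidin-3-yl group, an at least 2.8-fold lower number from compound 2 to compound 4 (0.45 log units; beyond the scatter), although the value for compound 2 is a limit and not a number, so the true size of this step is unknown: the limit of > 10000 nM in this assay, at which 1 of the 4 values shown sits.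

Going by these compounds, whether the number keeps rising with a butyl chain, or with a branched chain such as isopropyl on the nitrogen, remains open, as one step cannot establish a trend. On these data alone, it is also open how a primary amine, with only hydrogen on the nitrogen, or a ring amine such as piperidine would compare with methylamino.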